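Ring-nitrogen substituent size in the nitrile series

This account rests on a few compounds, and the source may have more. Where it says the series, first, only, none or still open, it means among the compounds named here.

Compound 2 `N#C[C@@]1(NC(=O)[C@@H](CC(=O)N2CCOCC2)CC2CCCCC2)CCN(C2CCCC2)C1` gives 75 nM in an assay on isolated protein for inhibition of cathepsin S (Homo sapiens) (on this read-out higher numbers stand for weaker inhibition and lower numbers for stronger inhibition), the highest of the three numbers recorded. Compound 1 `CC1CCC(C[C@H](CC(=O)N2CCOCC2)C(=O)N[C@]2(C#N)CCN(C3CCCCC3)C2)CC1` gives 14 nM in this assay, and compound 3 `N#C[C@H](COCc1ccccc1)NC(=O)[C@@H](CC(=O)N1CCOCC1)CC1CCCCC1` gives 37 nM; both lie beyond the scatter from compound 2, which therefore stands as the weakest of the three measured. For the measured compounds named here, compound 1 differs from compound 2 in two places at once, so no single step can be drawn between them.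

Compound 4 `N#C[C@@]1(NC(=O)[C@@H](CC(=O)N2CCOCC2)CC2CCCCC2)CCN(C2CCCCCC2)C1` has not yet been measured. It differs from compound 2 as follows: cycloheptyl in place of cyclopentyl on an amine nitrogen in a ring. Going by the values given here, no measured pair shows the effect of changing the size of this ring alone, so the direction of the step rests on the general picture of compound 1, whose value 14 nM is reached with a larger substituent on the same ring nitrogen. A modest gain is expected, probably near the edge of the scatter. Compound 4 is estimated at 45 nM in this assay, in a range of 15 nM to 140 nM, which would mean an expected step of a 1.7-fold lower number from compound 2 to compound 4 (0.22 log units; within the scatter).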

Compound 4, half-maximal inhibitory concentration: 23 nM
Estimate against measurement, compound 4: 2.0-fold (0.29 log units) above; the measured number falls inside the stated range.
By their numbers in this assay, from the lowest: compounds 1, 4 and 3 (each within the scatter of the next, the first and the last beyond it); then compound 2.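

The ring nitrogen now has its first single-change comparison: in this assay, cycloheptyl in place of cyclopentyl on this amine nitrogen gives a 3.3-fold lower number from compound 2 to compound 4 (0.51 log units; beyond the scatter), with the rest of the structure shared. The earlier compounds shown here could not isolate this position, since compound 1 differs from compound 2 in two places at once. Nothing among the available data accounts for this step.

Two ring sizes do not define a trend, and among the compounds shown, cyclohexyl on this nitrogen occurs only in compound 1, which also carries a different side chain, so the shape of the size dependence remains open. Also open, on these data alone, is how an open-chain group such as isobutyl, or a cycloheptyl ring carrying an amine or a carboxylic acid, would read out on this nitrogen.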